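The compounds below may be only part of what the source reports. "The series", "measured", "known", "first", "only" and "open" are said of these compounds alone.

Compound 2 `OC[C@H]1O[C@@H](n2cnc3c(NCc4ccc(Br)cc4)ncnc32)[C@H](O)[C@@H]1O` is one of three compounds built on a shared core and examined in a functional assay on HOS cells (Homo sapiens) for antiproliferative activity, with a stated time of 72 h; on this read-out lower numbers stand for stronger inhibition and higher numbers for weaker inhibition. In this assay compound 2 gives only a limit, > 166000 nM. Compound 1 `OC[C@H]1O[C@@H](n2cnc3c(NCc4cccc(Br)c4)ncnc32)[C@H](O)[C@@H]1O`, carrying 3-bromophenyl on a saturated chain carbon bound to a nitrogen on an aromatic ring, likewise gives only a limit in this assay, > 166000 nM. The step that the two limits leave unreadable from compound 1 to compound 2 is therefore unreadable, both values sitting at the limit of > 166000 nM in this assay, at which 2 of the 3 values shown sit. For compound 3 `COc1cc(CNc2ncnc3c2ncn3[C@@H]2O[C@H](CO)[C@@H](O)[C@H]2O)cc(OC)c1` this assay reports "not determined" (no result reported). Compound 4 `OC[C@H]1O[C@@H](n2cnc3c(NCc4cc(O)cc(O)c4)ncnc32)[C@H](O)[C@@H]1O` differs from compound 2 thus: 3,5-dihydroxyphenyl in place of 4-bromophenyl on a saturated chain carbon bound to a nitrogen on an aromatic ring. No readable measured step bears on this change. Compound 4 is therefore expected to remain near the limit, an estimated step of an at least 1.1-fold lower number from compound 2 to compound 4 (0.04 log units; that floor lies within the scatter). The estimate for compound 4 in this assay is 150000 nM, ranging from 40000 nM to 500000 nM.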

Compound 4, half-maximal inhibitory concentration: > 166000 nM
Compound 4 was reported as a limit; the forecaster's own chance of this, stated with the estimate: 70%; middle value at least 1.1-fold (0.04 log units) away from the limit.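

For the compounds shown here, no step to compound 4 can be read from compound 1 or compound 2 in this assay, since all three give only a limit: the limit of > 166000 nM in this assay, at which 3 of the 4 values shown sit. The compounds shown leave open whether any group at this place gives a value short of that limit.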